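The compounds below may be only part of what the source reports. "The series", "measured", "known", "first", "only" and "open" are said of these compounds alone.

Measured so far:
compound 1, `O=C(Nc1cccc(-n2cc(-c3ccncc3)c(-c3cc(O)cc(Cl)c3)n2)c1)Nc1ccc(Cl)c(C(F)(F)F)c1`, gives 102% in a functional assay on UACC-62 cells (Homo sapiens) for inhibition, read by sulforhodamine B assay, with a stated time of 48 h, tested at 0.1 uM; a lower number here means a stronger effect, a higher number a weaker effect of the compound at the concentration tested;
compound 2, `COc1cc(Cl)cc(-c2nn(-c3cccc(NC(=O)Nc4cc(C(F)(F)F)cc(C(F)(F)F)c4)c3)cc2-c2ccncc2)c1`, gives 92% in this assay.

Both compounds share the same core and differ in the urea-linked aryl ring and in the substituent on the phenol-bearing ring. In this assay compound 2 gives 92%, and the value of compound 1 in this assay lies within the usual scatter of that number, so the two compounds cannot be told apart on these data; neither shows a clear effect at the concentration tested. Among the compounds with values here, no step between measured compounds that differ in a single place is available, so there is no measured guide to the size of such a change.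

Compound 3, `COc1cc(Cl)cc(-c2nn(-c3cccc(NC(=O)Nc4cccc(C(F)(F)F)c4)c3)cc2-c2ccncc2)c1`, differs from compound 2 in one place: hydrogen in place of trifluoromethyl on an aromatic carbon.

Given that compound 2 gives 92% in this assay and compound 1 sits within the scatter of it, the loss of one trifluoromethyl group is expected to produce no step beyond the scatter, with a number 3 percentage points higher from compound 2 to compound 3 (within the scatter) estimated as essentially flat. For compound 3 the estimate in this assay is 95%, with a range from 80% to 110%.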

Compound 3, a percentage reported as activity, at one concentration (the size of the read-out at that concentration, not a potency): 96%
Compound 3: the middle estimate sits 1 percentage points below what was measured, and the stated range covers the measured number.
By their numbers in this assay, from the lowest: compounds 2, 3 and 1 (each within the scatter of the next).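

In this assay, within the data shown here, hydrogen in place of trifluoromethyl gives a number 4 percentage points higher from compound 2 to compound 3 (within the scatter), the first step in this set that changes one place only. Compound 2 and compound 3 therefore cannot be told apart, so this aromatic carbon, meta to a large group, can lose a trifluoromethyl group of 4 heavy atoms with no change that these data can resolve; because all three compounds lie close to one another and none shows a clear effect at the concentration tested, this flat step says little about how much this position matters for activity. No measurement at hand offers an explanation for this result.

Going by these compounds, it remains open whether a different group on this carbon, such as an amine or a carboxylic acid, would move the number beyond the scatter. On these data alone, it is equally open whether the same exchange of trifluoromethyl for hydrogen would stay as flat at a concentration where these compounds give a clear effect, or on a compound carrying the hydroxy group of compound 1.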